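Chloro-methylphenyl replaces ethylphenyl in a spiro antiproliferative series

This account rests on a few compounds, and the source may have more. Where it says the series, first, only, none or still open, it means among the compounds named here.

The series is judged in a functional assay on HCT-116 cells (Homo sapiens) for antiproliferative activity, read by MTT assay, with a stated time of 48 h; on this read-out lower numbers stand for stronger inhibition and higher numbers for weaker inhibition. Compound 1 `N#CC1=C(N)Oc2c(c3nc4ccccc4nc3c3ccccc23)C12C(=O)N(Cc1cnnn1-c1cccc(Br)c1)c1ccccc12` does not give a number there; it is reported only as a limit, > 50000 nM. Compound 2 `CCc1ccccc1-n1nncc1CN1C(=O)C2(C(C#N)=C(N)Oc3c(N)cc4nc5ccccc5nc4c32)c2ccccc21` is the one member with a measured value, giving 10300 nM in this assay, so it stands alone among the numbers shown. The other entry, that of compound 1, is a limit (the limit of > 50000 nM in this assay, at which 1 of the 2 values shown sits). Compound 3 `Cc1ccc(Cl)cc1-n1nncc1CN1C(=O)C2(C(C#N)=C(N)Oc3c(N)cc4nc5ccccc5nc4c32)c2ccccc21` keeps the shared core of compound 2 and differs from it in one place: 5-chloro-2-methylphenyl in place of 2-ethylphenyl on an aromatic nitrogen. For the measured compounds named here, no measured pair in this set shows what such a change does, so the step from compound 2 to compound 3 is expected to be small, estimated as a 1.3-fold lower number from compound 2 to compound 3 (0.11 log units; within the scatter) in this assay, at most a modest gain. Compound 3 is therefore expected to give about 8000 nM in this assay, estimated between 3000 nM and 25000 nM.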

Compound 3, half-maximal inhibitory concentration: 37200 nM
For compound 3 the middle estimate is 4.7-fold (0.67 log units) below the measured one, and the stated range ends below it.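

For the compounds shown here, this is the first measured step at this position, the aryl group on an aromatic nitrogen of the five-membered ring with 3 nitrogen. In this assay, 5-chloro-2-methylphenyl in place of 2-ethylphenyl gives a 3.6-fold higher number from compound 2 to compound 3 (0.56 log units; beyond the scatter) and so weakens the antiproliferative effect modestly, beyond the scatter. The two groups have the same heavy-atom count and the same single six-membered aromatic ring of carbon only, so the read-out responds here to a change that leaves those counts untouched, and nothing measured here accounts for the step.

The step from compound 2 to compound 3 shortens ethyl to methyl and adds chlorine together, leaving their separate contributions unresolved. The compounds shown also leave open how this position would respond to an amine or a carboxylic acid on the phenyl ring.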